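A few compounds are considered here, and "the series" means these few. Any claim that something is new, unique, unknown or untested is made for them only; others in the source may bear on it.

Measured in a physicochemical assay, read by spectrophotometry, with a stated time of 30 min; on this read-out higher numbers stand for weaker inhibition and lower numbers for stronger inhibition:
- compound 1 `O=C(CC(c1ccccc1Cl)c1c[nH]c2ccccc12)c1c(O)c2ccccc2oc1=O`: 39.6 ug/mL
- compound 2 `COc1ccc(OC)c(C(CC(=O)c2c(O)c3ccccc3oc2=O)c2c[nH]c3ccccc23)c1`: 19 ug/mL
- compound 3 `O=C(CC(c1ccc(O)cc1)c1c[nH]c2ccccc12)c1c(O)c2ccccc2oc1=O`: 58.9 ug/mL

In this assay, compound 3 gives 58.9 ug/mL. The comparison with its first neighbour shows a 1.5-fold higher number from compound 1 to compound 3 (0.17 log units; within the scatter), so those two cannot be told apart. The comparison with its other neighbour shows a 3.1-fold higher number from compound 2 to compound 3 (0.49 log units; beyond the scatter), a real but modest gap.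

Compound 4 `O=C(CC(c1ccc(O)c(O)c1)c1c[nH]c2ccccc12)c1c(O)c2ccccc2oc1=O` keeps everything in compound 3 except for one change: hydroxy in place of hydrogen on an aromatic carbon. This is hydroxy in place of hydrogen on an aromatic carbon, ortho to a hydroxy group, so 4-hydroxyphenyl becomes 3,4-dihydroxyphenyl.

Among the measured compounds shown here, no measured step makes this exact change. The closest evidence comes from swaps of the same aryl group, which gave a 2.1-fold lower number from compound 1 to compound 2 (0.32 log units; beyond the scatter) as well as the two steps above. Swaps at this spot have therefore moved the number only modestly. For the measured compounds named here, the direction is less certain, but compound 2, the one measured compound with two oxygen-linked groups on this ring, gives 19 ug/mL. On that slim basis, a modest fall is expected, and the estimated change is a 2.5-fold lower number from compound 3 to compound 4 (0.39 log units; beyond the scatter). Compound 4 is expected to give about 24 ug/mL, with an estimated range from 9 ug/mL to 50 ug/mL.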

Compound 4, half-maximal inhibitory concentration: 71.1 ug/mL
For compound 4 the middle estimate is 3.0-fold (0.47 log units) below the measured one; measured number above the stated range.
By their numbers in this assay, from the lowest: compound 2; then compounds 1, 3 and 4 (each within the scatter of the next).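

In this assay, adding a hydroxy to the ring of compound 3 makes no readable difference (a 1.2-fold higher number from compound 3 to compound 4 (0.08 log units; within the scatter)), so at this spot, ortho to a hydroxy group, hydrogen and hydroxy cannot be told apart. The 3,4-dihydroxyphenyl ring also stays level with the 2-chlorophenyl ring (a 1.8-fold higher number from compound 1 to compound 4 (0.25 log units; within the scatter)) but lies clearly apart from the 2,5-dimethoxyphenyl ring (a 3.7-fold higher number from compound 2 to compound 4 (0.57 log units; beyond the scatter)), which shows that two oxygen-linked groups on this ring do not by themselves give the low number of compound 2, whose steps to the other three compounds all lie beyond the scatter. No measurement available here explains why these two oxygen-bearing rings part ways.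

The compounds shown cannot separate the contribution of the methoxy groups in compound 2 from that of where they sit on the ring. They also leave open what an amine or a carboxylic acid would do in place of this same hydrogen, and whether a single methoxy there would match hydroxy or move the number toward that of compound 2.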